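Hydroxamate ureas: removing the aminomethyl group

This account rests on a few compounds, and the source may have more. Where it says the series, first, only, none or still open, it means among the compounds named here.

Measured compounds:
compound 1 `NCc1ccc(NC(=O)N(CCCCO)Cc2ccc(C(=O)NO)cc2)cc1` 498 nM
compound 2 `CCCCN(Cc1ccc(C(=O)NO)cc1)C(=O)Nc1ccc(CN)cc1` 614 nM

Among the measured compounds shown here, in an assay on HEK293 cells for inhibition of histone deacetylase 8 (Homo sapiens), read by fluorescence, with stated times of 10 min and 30 min (on this read-out higher numbers stand for weaker inhibition and lower numbers for stronger inhibition), compound 1 gives 498 nM, the lowest of the two numbers so far; compound 2 gives 614 nM, and the step of a 1.2-fold higher number from compound 1 to compound 2 (0.09 log units; within the scatter) lies within the scatter.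

Compound 3 `O=C(NO)c1ccc(CN(CCCCO)C(=O)Nc2ccccc2)cc1` differs from compound 1 by hydrogen in place of aminomethyl on an aromatic carbon. For the measured compounds named here, no measured pair alters this part of the structure; the only step on record, a 1.2-fold higher number from compound 1 to compound 2 (0.09 log units; within the scatter), concerns the hydroxy on the chain and says nothing about the aromatic ring. The expectation for compound 3 therefore rests on compound 1 alone, with a wide range to cover the loss of a donor and acceptor of unknown weight.

Compound 3 is expected to give 800 nM in this assay, within 250 nM to 2500 nM, which means an estimated step of a 1.6-fold higher number from compound 1 to compound 3 (0.21 log units; within the scatter).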

Compound 3, half-maximal inhibitory concentration: 478 nM
Estimate against measurement, compound 3: 1.7-fold (0.22 log units) above; the range from low to high includes it.
By their numbers in this assay, from the lowest: compounds 3, 1 and 2 (each within the scatter of the next).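

In this assay, among the compounds shown here, hydrogen in place of aminomethyl on the aromatic carbon gives a 1.0-fold lower number from compound 1 to compound 3 (0.02 log units; within the scatter), the first measured step at this position. On the core of compound 1, the aminomethyl group, with the hydrogen-bond donor and acceptor counted with it, can therefore be removed without a step beyond the scatter. No available evidence bears on why the read-out holds across this change.

The compounds shown leave open whether a different group on this aromatic carbon, such as a carboxylic acid, a dimethylamino group or a longer aminoalkyl chain, would give a step beyond the scatter. They also leave open whether hydrogen on this carbon gives a similar read-out when combined with the chain of compound 2, which lacks the hydroxy.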